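The source may hold more compounds than are shown below. What is called first, only, known or untested is meant among the compounds shown, and "the series" means these compounds.

Compound 3 `COc1cc([C@H]2c3[nH]c4ccccc4c3C[C@@H]3C(=O)N4[C@@H](c5cc(OC)c(O)c(OC)c5)c5[nH]c6ccccc6c5C[C@@H]4C(=O)N23)cc(OC)c1O` stands lowest of the three measured compounds in a functional assay on PC-3 cells (Homo sapiens) for cytotoxicity, tested at 50 uM; a higher number here means a weaker effect of the compound at the concentration tested, a lower number a stronger effect: compound 3 gives 43.6%, while compound 1 `COc1cc([C@@H]2c3[nH]c4ccccc4c3C[C@H]3C(=O)N4[C@H](c5cc(OC)c(OCc6ccccc6)c(OC)c5)c5[nH]c6ccccc6c5C[C@H]4C(=O)N23)cc(OC)c1OCc1ccccc1` gives 68.8% and compound 2 `COc1cc([C@H]2c3[nH]c4ccccc4c3C[C@@H]3C(=O)N4[C@@H](c5cc(OC)c(OCc6ccccc6)c(OC)c5)c5[nH]c6ccccc6c5C[C@@H]4C(=O)N23)cc(OC)c1OCc1ccccc1` gives 92.7%. Compound 4 `COc1cc([C@@H]2c3[nH]c4ccccc4c3C[C@H]3C(=O)N4[C@H](c5cc(OC)c(O)c(OC)c5)c5[nH]c6ccccc6c5C[C@H]4C(=O)N23)cc(OC)c1O` differs from compound 3 in this way: the two compounds have the same atoms and bonds and differ only in configuration as drawn: 4 of 4 stereo elements differ (all stereocentres are inverted: mirror images); a stereocentre at a saturated ring carbon is drawn S in compound 3 and R in compound 4; a stereocentre at a saturated ring carbon is drawn R in compound 3 and S in compound 4; a stereocentre at a saturated ring carbon is drawn S in compound 3 and R in compound 4; a stereocentre at a saturated ring carbon is drawn R in compound 3 and S in compound 4. Going by the values given here, one measured step bears on it, the mirror-image pair, which moved a number 23.9 percentage points higher from compound 1 to compound 2 (beyond the scatter), a change that rests on (the fact that compounds 1 and 2 differ only in the configuration as drawn). Compound 3 is drawn with the configuration of compound 2 and compound 4 with that of compound 1, so a shift of about the same size but toward a lower number is expected. Compound 4 is therefore estimated to give 22%, between 5% and 45%. That would mean an expected step of a number 21.6 percentage points lower from compound 3 to compound 4 (beyond the scatter).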

Compound 4, a percentage reported as activity, at one concentration (the size of the read-out at that concentration, not a potency): 3.3%
Beside the measured number, compound 4's estimate is 18.7 percentage points above it, and the stated range ends above it.
By their numbers in this assay, from the lowest: compound 4; then compound 3; then compound 1; then compound 2.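

Inverting every stereocentre of compound 3 gives a number 40.3 percentage points lower from compound 3 to compound 4 (beyond the scatter) in this assay, a change that rests on configuration alone: the fact that compounds 3 and 4 differ only in the configuration as drawn Set beside a number 23.9 percentage points higher from compound 1 to compound 2 (beyond the scatter), this shows that the configuration drawn in compound 1 and compound 4 gives the lower number in both mirror-image pairs, so the order is not confined to the benzyl ethers but also holds for the free hydroxyl compounds.

The compounds shown leave open whether this order would hold with an amine or a carboxylic acid in place of the hydroxyl groups. They also leave open how forms with only some stereocentres inverted would compare.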